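From compound 2 to compound 3: working notes

The source may report more compounds than this note shows. Statements on the series, on what has been measured and on what is new or still open speak of the compounds shown alone.

Measured in a functional assay on DU-145 cells (Homo sapiens) for inhibition, read by trypan blue exclusion, with a stated time of 96 h; a higher number here means a weaker inhibitor of growth, a lower number a stronger inhibitor of growth:
- compound 1 `Cc1ccc(S(=O)(=O)/C(=C/c2ccc(N(C)C)cc2)C(=O)c2ccc(Cl)cc2)cc1`: > 100000 nM (a limit)
- compound 2 `Cc1ccc(S(=O)(=O)/C(=C/c2cc(C)ccc2C)C(=O)c2ccc(Cl)cc2)cc1`: 1000 nM

Within the data shown here, compound 2 holds the only actual number so far, 1000 nM. For compound 1 the reading is only a limit, (the limit of > 100000 nM in this assay, at which 1 of the 2 values shown sits). Among the measured compounds shown here, the one measured step, an at least 100-fold lower number from compound 1 to compound 2 (2.00 log units; beyond the scatter), is large and lies at the same place as the change now in view, though it rests on that limit.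

Compound 3 `Cc1ccc(S(=O)(=O)/C(=C/c2cccs2)C(=O)c2ccc(Cl)cc2)cc1` carries thiophen-2-yl in place of 2,5-dimethylphenyl on a double-bonded chain carbon bound to a double-bonded chain carbon. For the measured compounds named here, no measured compound has this group, so the size of the step is poorly fixed. Going by the values given here, the step from compound 1 shows that this place can move the number strongly in this assay, and 2,5-dimethylphenyl is the only group here with a number, so a higher number is the likelier direction. The expected step is moderate: a 3.0-fold higher number from compound 2 to compound 3 (0.48 log units; beyond the scatter). For compound 3 the estimated value is 3000 nM, with an expected range from 500 nM to 20000 nM.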

Compound 3, concentration for 50% growth inhibition: 25000 nM
For compound 3 the middle estimate is 8.3-fold (0.92 log units) below the measured one, and the stated range ends below it.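

In this assay, the place on a double-bonded chain carbon bound to a double-bonded chain carbon now has a step with a real number at both ends (a 25-fold higher number from compound 2 to compound 3 (1.40 log units; beyond the scatter)), so its strong effect on the number no longer rests on a limit alone. Thiophen-2-yl thus falls well short of 2,5-dimethylphenyl here, yet it still differs from 4-(dimethylamino)phenyl, with an at least 4.0-fold lower number from compound 1 to compound 3 (0.60 log units; beyond the scatter) as the second new step, which places the three groups in a clear order in this assay. Compound 1 gives only a limit and not a number, so that second step is a bound on the size and not the size itself: the limit of > 100000 nM in this assay, at which 1 of the 3 values shown sits.

The change from compound 2 to compound 3 alters ring size, brings in the sulfur and removes the methyl groups in one step, and the compounds shown cannot separate these parts. On these data alone, how a plain phenyl, a 2-methylphenyl or a furan-2-yl would read at this place stays open, as does whether the order of groups holds with anything other than the 4-chlorophenyl carbonyl of this series.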